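A Hydroxy Group Tested on a Second Core

A few compounds are considered here, and "the series" means these few. Any claim that something is new, unique, unknown or untested is made for them only; others in the source may bear on it.

In a functional assay on HT-29 cells (Homo sapiens) for cytotoxicity, read by XTT assay, with a stated time of 72 h (a higher number here means a weaker inhibitor, a lower number a stronger inhibitor), compound 1 `CCn1ccc2cc(Cc3cc(OC)c(OC)c(OC)c3)ccc21` gives 35 nM. Compound 3 `CCn1ccc2cc(C(O)c3cc(OC)c(OC)c(OC)c3)ccc21` differs from it by hydroxy in place of hydrogen on a saturated chain carbon bound to two aromatic carbons. In this assay compound 3 reaches only a limit of the assay, > 10000 nM. The step is an at least 280-fold higher number from compound 1 to compound 3 (2.45 log units; beyond the scatter), and it rests on (the limit of > 10000 nM in this assay, at which 1 of the 3 values shown sits). Compound 2 `CCn1ccc2cc(Cc3ccc(OC)c(OC)c3OC)ccc21` is built from the same atoms as compound 1, joined differently; the difference between the two cores is not broken down here. In this assay compound 2 likewise reaches only a limit of the assay, > 1000 nM, which is the limit of > 1000 nM in this assay, at which 1 of the 3 values shown sits. Compound 4 `CCn1ccc2cc(C(O)c3ccc(OC)c(OC)c3OC)ccc21` differs from compound 2 by hydroxy in place of hydrogen on a saturated chain carbon bound to two aromatic carbons, the same change that separates compound 1 and compound 3. Among the measured compounds shown here, since the measured pair already shows a large loss, and compound 2 starts at a limit, the expected step is a step that the limit leaves unreadable from compound 2 to compound 4, set beside the measured step because an at least 280-fold higher number from compound 1 to compound 3 (2.45 log units; beyond the scatter) is the only measurement of this change here. Compound 4 is therefore estimated at 30000 nM, most probably reported again only as a limit.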

Compound 4, half-maximal inhibitory concentration: > 10000 nM
Compound 4: a limit, no number; the forecaster's own chance of this, stated with the estimate: 90%; the middle value does not contradict the limit.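

In this assay, compound 2 and compound 4 are both reported only as limits, so no step can be read between them for hydroxy in place of hydrogen on a saturated chain carbon bound to two aromatic carbons. The compounds shown leave open how large this change is on the core of compound 2, and whether it matches the loss seen on the core of compound 1.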